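This account rests on a few compounds, and the source may have more. Where it says the series, first, only, none or still open, it means among the compounds named here.

Compound 1 `COc1ccc(/C=C2/N=C(c3ccccc3)N(C(=O)c3ccc(Cl)cc3)NC2=O)cc1` and compound 2 `Cc1ccc(/C=C2/N=C(c3ccccc3)N(C(=O)c3ccc(Cl)cc3)NC2=O)cc1` share one core and differ only in a group on one of the outer rings. In a functional assay on the whole organism (strain albino) with Mus musculus as the target, with a stated time of 4 h (on this read-out lower numbers stand for an effect already at smaller amounts and higher numbers for an effect only at larger amounts of compound), compound 1 gives 300 mg/kg, the higher of the two numbers recorded, while compound 2 gives 100 mg/kg. Going by the values given here, the one measured step, a 3.0-fold lower number from compound 1 to compound 2 (0.48 log units; beyond the scatter), exchanges methyl for methoxy on an aromatic carbon and so concerns a different place than the change now followed.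

Compound 3 `COc1ccc(/C=C2/N=C(c3ccccc3)N(C(=O)c3ccc(C)cc3)NC2=O)cc1` differs from compound 1 by methyl in place of chloro on an aromatic carbon. Among the compounds with values here, no measured step involves chloro giving way to methyl at this place, so the data give no direct guide; the only step recorded lies elsewhere in the molecule and was modest.

With nothing to point either way, the number for compound 3 is expected to stay near that of compound 1, a step of a 1.2-fold lower number from compound 1 to compound 3 (0.08 log units; within the scatter), and the estimate is 250 mg/kg within 100 mg/kg to 600 mg/kg.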

Compound 3, dose for half-maximal effect: 30 mg/kg
Compound 3: the middle estimate sits 8.3-fold (0.92 log units) above what was measured; measured number below the stated range.
By their numbers in this assay, from the lowest: compound 3; then compound 2; then compound 1.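

Until now, only a change on the other outer ring had been seen. The exchange of chloro for methyl, para to a large group, shows that this ring also matters in this assay, with a 10-fold lower number from compound 1 to compound 3 (1.00 log units; beyond the scatter) and a step beyond the usual scatter. Chloro and methyl match in heavy-atom count and neither brings a hydrogen-bond donor or acceptor, yet this single swap is not neutral, and no measurement at hand explains the shift.

From the compounds shown here alone, whether fluoro, an amine or a longer chain such as ethyl at this place would push the number lower or higher stays open. Also open, going by these compounds, is what methyl at both changed places would give; compound 2 and compound 3 differ in two places and cannot be compared directly.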